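A few compounds are considered here, and "the series" means these few. Any claim that something is new, unique, unknown or untested is made for them only; others in the source may bear on it.

Compounds measured in an assay on isolated protein for inhibition of phosphodiesterase 7 (Homo sapiens), read by scintillation proximity assay and cAMP accumulation, with a stated time of 1 h (on this read-out lower numbers stand for stronger inhibition and higher numbers for weaker inhibition), so far:

compound 1 `N#Cc1ccccc1-c1ccc(CSc2nc(C(Cl)(Cl)Cl)nc3ccccc23)cc1` — > 100000 nM
compound 2 `CC(C)c1nc(SCc2ccc(-c3ccccc3C#N)cc2)c2ccccc2n1` — > 100000 nM
compound 3 `N#Cc1ccccc1-c1ccc(CSc2nc(SCc3ccc([N+](=O)[O-])cc3)nc3ccccc23)cc1` — > 100000 nM

All three values are limits of this assay, not numbers. Compound 1 sits at the limit with > 100000 nM in this assay. Compound 2 likewise gives only the limit > 100000 nM in this assay. Compound 3 also gives only the limit > 100000 nM in this assay. Hence (the limit of > 100000 nM in this assay, at which 3 of the 3 values shown sit). The steps a step that the two limits leave unreadable from compound 1 to compound 2, a step that the two limits leave unreadable from compound 1 to compound 3 and a step that the two limits leave unreadable from compound 2 to compound 3 cannot be sized, since both ends of each sit at the limit.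

The next compound, compound 4 `CC(C)c1nc(SCc2ccc(-c3cccc(C(=O)O)c3)cc2)c2ccccc2n1`, keeps the core of compound 2 and changes the distal aryl group: 3-carboxyphenyl in place of 2-cyanophenyl on an aromatic carbon. Going by the values given here, none of the measured steps touches this part of the molecule; they all vary the group on the other aromatic carbon of the shared core, and none of them yields a readable size. So no measured step bears on the change from compound 2 to compound 4, and no direction can be read from the data.

Compound 4 is therefore expected to remain at or near the limit, with an estimate of 100000 nM (range 20000 nM to 300000 nM) in this assay. The step from compound 2 to compound 4 is expected to be a number no higher from compound 2 to compound 4 (the limit leaves the size open), that is, none beyond the scatter, most likely reported again as a limit.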

Compound 4, half-maximal inhibitory concentration: 850 nM
For compound 4 the middle estimate is 120-fold (2.07 log units) above the measured one, outside the stated range (below it).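

In this assay, going by these compounds alone, 3-carboxyphenyl in place of 2-cyanophenyl on an aromatic carbon gives an at least 110-fold lower number from compound 2 to compound 4 (2.07 log units; beyond the scatter), the only step that can be read; the steps among compounds 1, 2 and 3 cannot be read. Within the data shown here, compound 4 gives 850 nM, a number rather than a limit, so the distal aryl group, which none of the earlier steps touched, can move the read-out with the isopropyl group held in place on the shared core. The remaining compounds offer nothing to set this number against, and each of their values is a limit and not a number: the limit of > 100000 nM in this assay, at which 3 of the 4 values shown sit.

Open, from the compounds shown here alone, is whether the step belongs to the carboxylic acid itself or to its place on the ring, since the nitrile leaves and the carboxylic acid enters at a different place in one change, and whether a methyl ester or a primary amide at the same place would also give a number. Also open, going by these compounds, is whether 3-carboxyphenyl gives a number when trichloromethyl or (4-nitrobenzyl)sulfanyl replaces the isopropyl group.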